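Compound 3: what a capped acid may do

A few compounds are considered here, and "the series" means these few. Any claim that something is new, unique, unknown or untested is made for them only; others in the source may bear on it.

Compound 1 `CCCOC(=O)c1cccc(C(=O)Nc2cccc(-c3cc(C(=O)Nc4ccncc4F)ccc3CN)c2)c1` gives < 0.0834 h (a limit of the assay)
Compound 2 `NCc1ccc(C(=O)Nc2ccncc2F)cc1-c1cccc(NC(=O)c2cc(C(=O)O)ccc2F)c1` gives > 2 h (a limit of the assay)

In an ADME assay on a cell-free system (plasma, Homo sapiens) for metabolic stability, read by LC-MS (on this read-out higher numbers stand for a longer-lived compound and lower numbers for a shorter-lived compound), compound 2 gives > 2 h as a limit of the assay, not a number. Compound 3 `COCCOC(=O)c1ccc(F)c(C(=O)Nc2cccc(-c3cc(C(=O)Nc4ccncc4F)ccc3CN)c2)c1` differs from it by 2-methoxyethyl in place of hydrogen on an oxygen next to a carbonyl group with 2-methoxyethyl in place of hydrogen on an oxygen next to a carbonyl group, turning carboxy into (2-methoxyethoxy)carbonyl. Compound 3 again has a chain on that oxygen, so going by an at least 23-fold higher number from compound 1 to compound 2 (1.37 log units; beyond the scatter) (large, beyond the scatter, with 5-carboxy-2-fluorophenyl in place of 3-(propoxycarbonyl)phenyl) a large step down is expected. The expected size is an at least 25-fold lower number from compound 2 to compound 3 (1.39 log units; beyond the scatter) in this assay as a drop. For compound 3 the estimate is 0.08 h within 0.03 h to 0.25 h and the result may come back as only a limit.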

Compound 3, half-life: < 0.0834 h
Compound 3 was reported as a limit; the forecaster's own chance of this, stated with the estimate: 60%; the middle value is on the limit's open side.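

In this assay there is an at least 23-fold lower number from compound 2 to compound 3 (1.37 log units; beyond the scatter) with a single change: 2-methoxyethyl in place of hydrogen on the oxygen of the carboxy group. The earlier step also moved from a ring without fluorine to one with it, and could not separate the two changes; here the fluorine stays, and capping the oxygen alone is enough for the drop. On these data alone, both ends of this step are limits of the assay, and its true size stays unknown.

Open, as far as these compounds go, is whether a smaller group on that oxygen, such as methyl, gives the same drop. Also open, from the compounds shown here alone, is how a primary amide in place of the ester would behave in this assay.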